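The source may hold more compounds than are shown below. What is called first, only, known or untested is meant among the compounds shown, and "the series" means these compounds.

Measured compounds: compound 1 `COC(=O)C#CC(O/C=C/C(=O)OC)C1CC1`, 250 nM; compound 2 `COC(=O)C#CC(O/C=C/C(=O)OC)C(C)(C)C`, 1800 nM.

Among the measured compounds shown here, in a functional assay on HBL-100 cells (Homo sapiens) for antiproliferative activity, read by sulforhodamine B assay, with a stated time of 48 h (a lower number here means a stronger inhibitor of growth, a higher number a weaker inhibitor of growth), compound 2 gives the higher of the two numbers; the sole measured step is a 7.2-fold higher number from compound 1 to compound 2 (0.86 log units; beyond the scatter). Compound 3 `COC(=O)/C=C/OC(C#CC(=O)O)C(C)(C)C` differs from compound 2 by hydrogen in place of methyl on an oxygen next to a carbonyl group, on an oxygen next to a carbonyl group. For the measured compounds named here, the one measured step alters a different part of the molecule and carries no information on this change, so no measured step bears on it. The direction in this assay is therefore open and the range must be wide. Compound 3 is expected to give 4000 nM (range 1000 nM to 20000 nM), an expected step of a 2.2-fold higher number from compound 2 to compound 3 (0.35 log units; beyond the scatter).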

Compound 3, concentration for 50% growth inhibition: > 100000 nM
Compound 3: only a limit was reported (the forecaster's own chance of this, stated with the estimate: 15%); middle value at least 25-fold (1.39 log units) away from the limit.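

In this assay compound 3 gives > 100000 nM, a limit of the assay and not a number. The change from 2-(methoxycarbonyl)ethynyl to 2-carboxyethynyl gives an at least 55-fold higher number from compound 2 to compound 3 (1.74 log units; beyond the scatter). This position, left unchanged between compound 1 and compound 2, is therefore sensitive: growth inhibition reads as a number with methoxycarbonyl, but only as a limit with carboxy.

As far as these compounds go, how a primary amide or an ethyl ester would read at this position stays open. So does the effect of the same change on the other methoxycarbonyl group, or with cyclopropyl in place of tert-butyl.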